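Ester Chain Changes and Stability in Mouse Liver Microsomes

The source may hold more compounds than are shown below. What is called first, only, known or untested is meant among the compounds shown, and "the series" means these compounds.

Measured in an ADME assay on microsomes from liver (Mus musculus) for metabolic stability, with a stated time of 30 min; a higher number here means that more of the compound is left, a lower number that less of the compound is left:
compound 1 `CCCCc1nc(C(C)C)c(CC(=O)OCCC)c(=O)n1Cc1ccc(-c2ccccc2-c2noc(=O)[nH]2)cc1`: 12.6%
compound 2 `CCCCc1nc(C(C)C)c(CC(=O)OCC(C)C)c(=O)n1Cc1ccc(-c2ccccc2-c2noc(=O)[nH]2)cc1`: 13.7%

Compound 2 and compound 1 sit side by side on the two numbers shown: a number 1.1 percentage points higher from compound 1 to compound 2 (within the scatter). Both share the same core and differ only in the chain of the ester.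

Compound 3 `CC#CCOC(=O)Cc1c(C(C)C)nc(CCCC)n(Cc2ccc(-c3ccccc3-c3noc(=O)[nH]3)cc2)c1=O` changes that ester chain again: prop-1-yn-1-yl in place of isopropyl on a saturated chain carbon bound to an oxygen next to a carbonyl group. Among the measured compounds shown here, the one measured step, from compound 1 to compound 2, also exchanged one ester chain for another, and it stayed within the scatter. For the measured compounds named here, no measured step exchanges a saturated chain for one carrying a triple bond, so the bearing of that step on compound 3 is indirect. On this basis, the expected step is a number 0.7 percentage points lower from compound 2 to compound 3 (within the scatter), meaning none beyond the scatter. Compound 3 is therefore estimated at 13% in this assay, with a range from 5% to 26%.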

Compound 3, percent of the compound remaining: 16.4%
Compound 3: the middle estimate sits 3.4 percentage points below what was measured; measured number inside the range.
By their numbers in this assay, from the lowest: compounds 1, 2 and 3 (each within the scatter of the next).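

In this assay, among the compounds shown here, the ester chain has now been changed in a different way: a triple bond enters for the first time, where the earlier step only added a methyl to a saturated chain. Prop-1-yn-1-yl in place of isopropyl, on a saturated chain carbon bound to an oxygen next to a carbonyl group, gives a small step (a number 2.7 percentage points higher from compound 2 to compound 3 (within the scatter)), and prop-1-yn-1-yl in place of ethyl gives another (a number 3.8 percentage points higher from compound 1 to compound 3 (within the scatter)), so at this position neither the branched nor the triple-bond chain stands apart from the others. Nothing available explains these numbers.

The compounds shown leave open whether a longer chain or an amine on this ester chain would change the number beyond the scatter. They also leave open which part of these compounds is lost during the incubation, and whether an amide in place of the ester would change that.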